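The source may hold more compounds than are shown below. What is called first, only, known or untested is meant among the compounds shown, and "the series" means these compounds.

Measured in an in vitro ADME assay on microsomes from liver (Simiiformes); on this read-out higher numbers stand for a longer-lived compound and lower numbers for a shorter-lived compound:
- compound 1 `Cc1cc(CCCOc2c(C)cc(-c3noc(C)n3)cc2C)on1`: 0.45 h
- compound 2 `COCc1cc(CCCOc2c(C)cc(-c3noc(C(F)(F)F)n3)cc2C)on1`: 1.58 h
- compound 3 `CCc1cc(CCCOc2c(C)cc(-c3noc(C4CC4)n3)cc2C)on1`: 0.9 h

In this assay, compound 2 stands clearly above compound 1, while its gap to compound 3 lies within the scatter. Compound 4 `Cc1cc(-c2noc(C(F)(F)F)n2)cc(C)c1OCCCc1cccc(F)n1` has not yet been measured. It differs from compound 2 as follows: 6-fluoropyridin-2-yl in place of 3-(methoxymethyl)-1,2-oxazol-5-yl on a saturated chain carbon, three bonds along the chain from an oxygen on an aromatic ring. Among the compounds with values here, no measured pair of compounds isolates a change in this place, so the data give no direction for it. The expectation therefore starts from compound 2 at 1.58 h, and no step beyond the scatter is expected. The estimated step of a 1.1-fold lower number from compound 2 to compound 4 (0.02 log units; within the scatter) is small. For compound 4 the expected half-life is estimated at 1.5 h, within a range of 0.6 h to 3.6 h.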

Compound 4, half-life: > 2.5 h
Compound 4 ended at the assay's limit (the forecaster's own chance of this, stated with the estimate: 5%); middle value at least 1.6-fold (0.22 log units) away from the limit.
By their numbers in this assay, from the lowest: compounds 1, 3 and 2 (each within the scatter of the next, the first and the last beyond it). At a limit, above all of these: compound 4.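

In this assay compound 4 gives > 2.5 h, a limit of the assay and not a number: the limit of > 2.5 h in this assay, at which 1 of the 4 values shown sits. Compounds 1, 2 and 3 all carry a five-membered aromatic ring at this place, whereas the six-membered 6-fluoropyridin-2-yl gives an at least 1.5-fold higher number from compound 2 to compound 4 (0.19 log units; that floor lies within the scatter). This position therefore tolerates that ring exchange without any loss of half-life, although the floor of the step lies within the scatter.

As far as these compounds go, how far the step really reaches stays open. So does whether the ring or its fluorine matters, which a plain pyridin-2-yl or a nitrile in place of the fluorine would address.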